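Lengthening Methyl to Propyl: What to Expect for Compound 3

The source may report more compounds than this note shows. Statements on the series, on what has been measured and on what is new or still open speak of the compounds shown alone.

Measured so far:
compound 1 `Cc1ccc(-c2cc(Cl)cc(C(=O)Nc3nn[nH]n3)n2)cc1`: 10%
compound 2 `COc1cc(C(=O)Nc2nn[nH]n2)nc(-c2ccc(C)cc2)c1`: 16%

In a functional assay on the whole organism for inhibition, with Rattus norvegicus as the target, at a dose of 0.3 mg/kg by the oral route (on this read-out higher numbers stand for a stronger effect at the one dose given and lower numbers for a weaker effect), compound 1 gives 10%. In this assay compound 2 gives 16%. Among the measured compounds shown here, of these two numbers the one for compound 2 is the higher, but the single step known, a number 6 percentage points higher from compound 1 to compound 2 (within the scatter), is within the scatter, so the two compounds cannot be told apart on this evidence. Both numbers are small.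

Compound 3 `CCCc1ccc(-c2cc(OC)cc(C(=O)Nc3nn[nH]n3)n2)cc1` is the next structure. It differs from compound 2 by ethyl in place of hydrogen on a saturated chain carbon bound to an aromatic carbon. For the measured compounds named here, no measured step touches this change: the only step known concerns the swap of methoxy for chloro on an aromatic carbon, a different place on the shared core. There is therefore nothing to suggest a move in either direction, and the expectation is a step of no size beyond the scatter, no change at the digits printed from compound 2 to compound 3 (within the scatter). Compound 3 is thus estimated at 16%, within a range of 0% to 40%.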

Compound 3, a percentage reported as inhibition, in the whole organism at one dose (the size of the read-out at that dose, not a potency): 32%
The estimate for compound 3 lay 16 percentage points below the measured number, within the range that was stated.
By their numbers in this assay, from the lowest: compounds 1 and 2 (each within the scatter of the next); then compound 3.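

In this assay, among the compounds shown here, lengthening methyl to propyl gives a number 16 percentage points higher from compound 2 to compound 3 (beyond the scatter), and this is the first step that clears the usual scatter of the read-out. The position on the saturated chain carbon bound to an aromatic carbon therefore responds to change, unlike the swap of methoxy for chloro, which gave a number 6 percentage points higher from compound 1 to compound 2 (within the scatter) and could not be told apart from no change. Nothing measured here accounts for the rise, which remains an observation without an explanation.

The compounds shown leave open whether a butyl chain would raise the number further or whether the rise ends at propyl. They also leave open whether propyl would give a similar step on the core of compound 1, which carries chloro in place of methoxy.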